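The source may report more compounds than this note shows. Statements on the series, on what has been measured and on what is new or still open speak of the compounds shown alone.

Three compounds have been measured in a functional assay on LOX IMVI cells (Homo sapiens) for inhibition, read by sulforhodamine B assay, with a stated time of 48 h, tested at 10 uM; a lower number here means less inhibition, a higher number more inhibition at the concentration tested (going by the name of the read-out):
compound 1 `Brc1cn2ccnc2c(-c2ccc3ncn(C4CCCCC4)c3c2)n1` gives 15.2%
compound 2 `O=Cc1ccc(-c2cn3ccnc3c(-c3ccc4ncn(C5CCCCC5)c4c3)n2)cc1` gives 46.9%
compound 3 `Fc1ccc(-c2cn3ccnc3c(-c3ccc4ncn(C5CCCCC5)c4c3)n2)cc1` gives 3.5%

Compound 3 stands lowest of the three: one gap is modest (a number 11.7 percentage points lower from compound 1 to compound 3 (beyond the scatter)) and the other is large (a number 43.4 percentage points lower from compound 2 to compound 3 (beyond the scatter)), both beyond the scatter. Compound 4 `c1cn2cc(-c3ccsc3)nc(-c3ccc4ncn(C5CCCCC5)c4c3)c2n1` differs from compound 3 at one site: thiophen-3-yl in place of 4-fluorophenyl on an aromatic carbon. Going by the values given here, no measured step swaps one aryl group for another; the two steps that bear on it replace bromo by an aryl group, with a large rise (a number 31.7 percentage points higher from compound 1 to compound 2 (beyond the scatter)) and a modest fall (a number 11.7 percentage points lower from compound 1 to compound 3 (beyond the scatter)). Thiophen-3-yl carries no formyl, so compound 4 is expected to land near compound 1 and compound 3 rather than near compound 2. The step of a number 8.5 percentage points higher from compound 3 to compound 4 (within the scatter) is expected to be small and upward. The estimate for compound 4 is 12%, within -8% to 32%.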

Compound 4, a percentage reported as inhibition, at one concentration (the size of the read-out at that concentration, not a potency): 4.9%
Beside the measured number, compound 4's estimate is 7.1 percentage points above it; measured number inside the range.
By their numbers in this assay, from the lowest: compounds 3 and 4 (each within the scatter of the next); then compound 1; then compound 2.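

In this assay, going by these compounds alone, this is the first direct exchange of one aryl group for another at this position, and thiophen-3-yl cannot be told apart from 4-fluorophenyl (a number 1.4 percentage points higher from compound 3 to compound 4 (within the scatter)). Replacing 4-formylphenyl by thiophen-3-yl gives a number 42 percentage points lower from compound 2 to compound 4 (beyond the scatter), and replacing bromo by thiophen-3-yl gives a number 10.3 percentage points lower from compound 1 to compound 4 (beyond the scatter), so of the three aryl groups shown only 4-formylphenyl stands above bromo. No evidence at hand accounts for these numbers.

Going by these compounds, it remains open whether the higher number with 4-formylphenyl is tied to the carbonyl, and how a phenyl ring carrying a carboxylic acid, an amine or a nitrile would read here.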